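A few compounds are considered here, and "the series" means these few. Any claim that something is new, unique, unknown or untested is made for them only; others in the source may bear on it.

Measured in a functional assay on SMMC-7721 cells (Homo sapiens) for antiproliferative activity, read by MTT assay, with a stated time of 48 h; a higher number here means a weaker inhibitor, a lower number a stronger inhibitor:
- Compound 1 `Cn1cc(C2=C(c3nn(CCn4ccnc4)c4ncccc34)C(=O)N(c3ccccc3)C2=O)c2ccccc21`: > 100000 nM
- Compound 2 `Cn1cc(C2=C(c3nn(CCCN4CCCCC4)c4ncccc34)C(=O)N(c3ccc(Cl)cc3)C2=O)c2ccccc21`: > 100000 nM
- Compound 3 `Cn1cc(C2=C(c3nn(CCCn4ccnc4)c4ncccc34)C(=O)N(c3ccccc3)C2=O)c2ccccc21`: 34800 nM

The values for compound 1 and compound 2 are limits, not numbers. Compound 2 stands at the limit of > 100000 nM in this assay, at which 2 of the 3 values shown sit, so there is no number to start from.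

Compound 4 `Cn1cc(C2=C(c3nn(CCCN4CCCCC4)c4ncccc34)C(=O)NC2=O)c2ccccc21` differs from compound 2 by one change, hydrogen in place of 4-chlorophenyl on an amide-type nitrogen in a ring.

Among the measured compounds shown here, only one measured step exists, an at least 2.8-fold lower number from compound 1 to compound 3 (0.45 log units; beyond the scatter). For the measured compounds named here, it lies on the chain, not at this nitrogen, and no measured pair tests the group being removed, so it offers only weak guidance. It does show that one small change can move a compound off the limit. Compound 3, at 34800 nM, also shows that this family can give a real number.

A modest move toward a lower number in this assay is therefore expected, although compound 4 may well stay at the limit. The expected change is an at least 2.8-fold lower number from compound 2 to compound 4 (0.45 log units; beyond the scatter). For compound 4 the estimated value is 35000 nM, with an expected range of 8000 nM to 100000 nM.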

Compound 4, half-maximal inhibitory concentration: 7670 nM
Beside the measured number, compound 4's estimate is 4.6-fold (0.66 log units) above it; the whole stated range lies above it.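

In this assay, hydrogen in place of 4-chlorophenyl on the amide-type nitrogen in a ring gives an at least 13-fold lower number from compound 2 to compound 4 (1.11 log units; beyond the scatter), so a change at this nitrogen, and not only on the chain, can move a compound off the limit. The size of this step is only a lower bound, as compound 2 has a limit and not a number: the limit of > 100000 nM in this assay, at which 2 of the 4 values shown sit. Compound 4 also shows that this family can give a number with no aromatic ring on this nitrogen.

The compounds shown leave open whether the whole 4-chlorophenyl group or only its chlorine matters, as no pair here separates the two. Going by these compounds, it is also open whether a methyl or a benzyl group on this nitrogen would give a value closer to that of hydrogen or to the limit.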